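A few compounds are considered here, and "the series" means these few. Any claim that something is new, unique, unknown or untested is made for them only; others in the source may bear on it.

Measured compounds:
Compound 1, `Cc1cc2occ(-c3nc(-c4ccccc4)c(-c4ccccc4)n3-c3ccccc3Cl)c(=O)c2cc1Cl`: in an ADME assay on MCF-10A cells (Homo sapiens) for cytotoxicity, read by MTT assay, with a stated time of 72 h (a lower number here means a stronger inhibitor, a higher number a weaker inhibitor), compound 1 gives "not determined" (no result reported).
Compound 2, `Cc1cc2occ(-c3nc(-c4ccccc4)c(-c4ccccc4)n3-c3cccc(Cl)c3)c(=O)c2cc1Cl`: in this assay compound 2 gives "not determined" (no result reported).
Compound 3, `Cc1cc2occ(-c3nc(-c4ccccc4)c(-c4ccccc4)n3-c3ccc(Cl)cc3)c(=O)c2cc1Cl`: in this assay compound 3 gives 92000 nM.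

Going by the values given here, compound 1 therefore stands without a number of its own in this assay, and compound 2 is in the same position; the only value among the three measured compounds belongs to compound 3. The unmeasured compound 4, `Cc1cc2occ(-c3nc(-c4ccccc4)c(-c4ccccc4)n3-c3ccc(Br)cc3)c(=O)c2cc1Cl`, differs from compound 1 in a single respect: 4-bromophenyl in place of 2-chlorophenyl on an aromatic nitrogen. Among the compounds with values here, no step between two measured compounds is available, so the size and direction of the change from compound 1 to compound 4 cannot be read from the data; the only anchor is the value of compound 3, a close relative of compound 4 that shares its overall core. On that basis compound 4 is expected to sit near compound 3, with no shift beyond the usual scatter anticipated. The estimate for compound 4 in this assay is 90000 nM, within a range from 30000 nM to 250000 nM.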

Compound 4, half-maximal inhibitory concentration: > 100000 nM
Compound 4 was reported as a limit; the forecaster's own chance of this, stated with the estimate: 35%; middle value at least 1.1-fold (0.04 log units) from the limit.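

In this assay compound 4 gives a limit and not a number: the limit of > 100000 nM in this assay, at which 1 of the 4 values shown sits. Bromo in place of chloro on an aromatic carbon, within the phenyl group on the aromatic nitrogen, gives an at least 1.0-fold higher number from compound 3 to compound 4 (0.03 log units; that floor lies within the scatter), the first step that can be read at this place, though it is only a floor and the full size of the step stays unknown. This exchange of halogen therefore brings no sign of a lower number in this assay.

Compound 1 has no number of its own, so its 2-chlorophenyl cannot be set against the 4-bromophenyl of compound 4. Also open, from the compounds shown here alone, is what a phenyl group carrying an amine or a carboxylic acid would give on the same aromatic nitrogen.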